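Nitro in Place of Bromo: Expected Tolerance of Compound 3

A few compounds are considered here, and "the series" means these few. Any claim that something is new, unique, unknown or untested is made for them only; others in the source may bear on it.

Compound 1 `CC(=O)Nc1ccc(OCc2nnc(SCC(=O)Nc3ccc(Cl)cc3)n2Cc2ccccc2)cc1` and compound 2 `CC(=O)Nc1ccc(OCc2nnc(SCC(=O)Nc3ccc(Br)cc3)n2Cc2ccccc2)cc1` share one core and differ only in the halogen on the outer ring. In a toxicity assay on MT4 cells (Homo sapiens) for cytotoxicity, read by MTT assay, with a stated time of 5 days (a lower number here means that less compound is tolerated, a higher number that more compound is tolerated), compound 1 gives 14 ug/mL. For compound 2 this assay reports only a limit, >= 3.99 ug/mL. Because of the limit of >= 3.99 ug/mL in this assay, at which 1 of the 2 values shown sits, the step that the limit leaves unreadable from compound 1 to compound 2 cannot be sized, so compound 2 stands at a limit rather than at a number. Compound 3 `CC(=O)Nc1ccc(OCc2nnc(SCC(=O)Nc3ccc([N+](=O)[O-])cc3)n2Cc2ccccc2)cc1` differs from compound 2 by nitro in place of bromo on an aromatic carbon. Within the data shown here, no measured step bears on this change, so no direction can be drawn from the data. Compound 3 is therefore expected near 10 ug/mL, between 3 ug/mL and 35 ug/mL, an estimated step that the limit leaves unreadable from compound 2 to compound 3.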

Compound 3, half-maximal cytotoxic concentration: 105 ug/mL
Estimate against measurement, compound 3: 11-fold (1.02 log units) below, and the stated range ends below it.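

Among these compounds, at this position on the outer ring, para to a large group, nitro in place of chloro gives a 7.5-fold higher number from compound 1 to compound 3 (0.88 log units; beyond the scatter) in this assay, the first step here that can be read. More of compound 3 is therefore tolerated than of compound 1, so the group at this position can shift the tolerated concentration beyond the scatter. The steps from compound 1 to compound 2 and from compound 2 to compound 3 cannot be read: the limit of >= 3.99 ug/mL in this assay, at which 1 of the 3 values shown sits.

From the compounds shown here alone, whether bromo differs from chloro here stays open. So does the reading for an amine or a carboxylic acid at this position.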